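Adding a Methyl to Compound 1

The source may report more compounds than this note shows. Statements on the series, on what has been measured and on what is new or still open speak of the compounds shown alone.

Compound 1 `O=C(Cc1cccnc1)c1cc2ccccc2[nH]1` was tested in an in vitro assay on P815B cells for inhibition of Indoleamine 2,3-dioxygenase 1 (Mus musculus), tested at 20 uM (a higher number here means more inhibition at the concentration tested (going by the name of the read-out), a lower number less inhibition), where compound 1 gives 13%. Going by the values given here, this is the only number the study offers: a second compound, compound 2 `COc1ccc2[nH]c(C(=O)Cc3cccnc3)cc2c1`, was included, but in this assay compound 2 is reported as "not determined" (no result reported), so compound 1 cannot be set against any other measured compound. On the one number shown, nothing can be said of whether the inhibition of compound 1 in this assay is higher or lower than that of any other compound.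

Compound 3 `CC(C(=O)c1cc2ccccc2[nH]1)c1cccnc1` has not yet been measured. It differs from compound 1 in a single place: methyl in place of hydrogen on a saturated chain carbon bound to an aromatic carbon and a carbonyl carbon. Among the compounds with values here, the group that enters is small, one carbon and no ring, and there is no measured pair in the study that shows what such a change does in this assay. Without such a guide, the step from compound 1 to compound 3 is expected to be close to none, within the usual scatter in either direction.

On that basis compound 3 is expected to show about 14% in this assay, with a range from 0% to 35%. The estimated change a number 1 percentage points higher from compound 1 to compound 3 (within the scatter) is expected to stay within the scatter.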

Compound 3, a percentage reported as inhibition, at one concentration (the size of the read-out at that concentration, not a potency): "not active" (no number reported)
Compound 3 has no reported number here; there is nothing to compare the estimate with.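

Going by these compounds alone, compound 3 is reported in this assay as "not active" (no number reported), without a number, so no step from compound 1 to compound 3 can be read. No other information available bears on this result. As far as these compounds go, what the methyl on the saturated chain carbon does to the size of the inhibition in this assay stays open.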